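The source may hold more compounds than are shown below. What is called first, only, known or untested is meant among the compounds shown, and "the series" means these compounds.

Compound 1 `O=S(=O)(c1ccccc1Cl)n1ccc2c(N3CCNCC3)cccc21` gives 0.398 nM in an assay on HeLa cells for displacement of a labelled ligand from 5-hydroxytryptamine receptor 6 (Homo sapiens); a lower number here means a stronger inhibitor, a higher number a weaker inhibitor. Among the measured compounds shown here, compound 2 `O=S(=O)(c1ccc(Cl)cc1)n1ccc2c(N3CCNCC3)cccc21` gives 2 nM there, the highest of the two numbers so far; the step of a 5.0-fold higher number from compound 1 to compound 2 (0.70 log units; beyond the scatter) is the only one measured and concerns the position of the chlorine alone. Compound 3 `O=S(=O)(c1ccccn1)n1ccc2c(N3CCNCC3)cccc21` differs from compound 2 by pyridin-2-yl in place of 4-chlorophenyl on a sulfonyl sulfur. For the measured compounds named here, no measured step bears on a heteroaryl in place of a chlorophenyl on the sulfonyl sulfur, so the step from compound 2 to compound 3 is expected to be small, within or near the scatter, with a modest rise in the number as the likelier side, a 1.5-fold higher number from compound 2 to compound 3 (0.18 log units; within the scatter). Compound 3 is therefore estimated at 3 nM, in a range from 1 nM to 10 nM.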

Compound 3, inhibition constant: 1 nM
Beside the measured number, compound 3's estimate is 3.0-fold (0.48 log units) above it, within the range that was stated.
By their numbers in this assay, from the lowest: compound 1; then compounds 3 and 2 (each within the scatter of the next).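

Among the compounds shown here, with pyridin-2-yl, the sulfonyl sulfur carries a ring without chlorine for the first time, and in this assay this ring cannot be separated from 4-chlorophenyl (a 2.0-fold lower number from compound 2 to compound 3 (0.30 log units; within the scatter)). Against 2-chlorophenyl, the same group gives a clearer difference (a 2.5-fold higher number from compound 1 to compound 3 (0.40 log units; beyond the scatter)), so compound 1 keeps the lowest number of the three. A low number at this position therefore does not depend on a chlorine on the ring. No measured evidence accounts for these differences.
Open, as far as these compounds go, is how an aryl ring bearing a methoxy group, an amine or a carboxylic acid would read at this position.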